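The compounds below may be only part of what the source reports. "The series", "measured", "known", "first", "only" and "open" are said of these compounds alone.

Measured compounds in a functional assay (trachea) with Rattus norvegicus as the target; on this read-out higher numbers stand for higher potency (the scale is a negative logarithm) and lower numbers for lower potency:
compound 1 `CC1(C)C=C(n2ccccc2=O)c2cc(C(=O)c3ccco3)ccc2O1` gives 5.92
compound 2 `CC1(C)C=C(n2ccccc2=O)c2cc(OCC(=O)c3ccc(F)cc3)ccc2O1` gives 4.77

Among the compounds with values here, compound 1 stands highest of the two numbers obtained in this assay; compound 2 lies below it by more than the scatter, and no single-point step connects the two structures, so their values are read only side by side. Compound 3 `CC1(C)C=C(n2ccccc2=O)c2cc(Br)ccc2O1` is not yet measured. It differs from compound 1 in one place: bromo in place of (furan-2-yl)carbonyl on an aromatic carbon. Within the data shown here, what enters on the shared core, bromo, has no counterpart among the measured pair, so neither the direction nor the size of the step can be taken from a precedent. A modest loss is expected in this assay, possibly still within the scatter, with a wide range on either side. For compound 3 the value expected in this assay is 5.6, between 4.8 and 6.4, which is expected to mean a step of a number 0.32 log units lower from compound 1 to compound 3 (beyond the scatter).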

Compound 3, logarithm of the reciprocal of the active concentration, log(1/C): 7.53
Compound 3: middle estimate off by 1.93 log units, on the low side; the measured number lies above the stated range.
By their numbers in this assay, from the lowest: compound 2; then compound 1; then compound 3.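

In this assay replacing (furan-2-yl)carbonyl with bromo on this aromatic carbon gives a number 1.61 log units higher from compound 1 to compound 3 (beyond the scatter) and marks this position as one where a single substituent change can move the read-out by a large step. High potency here does not depend on the five-membered aromatic ring, the double bond outside aromatic rings or the hydrogen-bond acceptors of the group that leaves: one bromine atom in place of seven heavy atoms gives the higher number. Nothing measured here explains the size of this step.

From the compounds shown here alone, how chloro, a plain hydrogen, an amine or a carboxylic acid on this aromatic carbon would compare with bromo remains open. Also open is whether the gain would hold with any change elsewhere on the shared core, as the compounds shown vary only at this position.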